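Turning a chloro substituent back into a methoxy substituent

The source may hold more compounds than are shown below. What is called first, only, known or untested is meant among the compounds shown, and "the series" means these compounds.

Measured compounds:
compound 1, `COc1cccc(NC(=S)NC2CC(C)(C)Oc3ccc(Br)cc32)c1`, 66000 nM
compound 2, `CC1(C)CC(NC(=S)Nc2cccc(Cl)c2)c2cc(Br)ccc2O1`, 8000 nM
compound 3, `O=[N+]([O-])c1cccc(NC(=S)NC2CCOc3ccc(Cl)cc32)c1`, 8000 nM

These three compounds share a thiourea linking a substituted phenyl ring to a bicyclic core, and were tested in a functional assay on U-373MG ATCC cells (Homo sapiens) for inhibition, read by MTT assay, with a stated time of 72 h; on this read-out higher numbers stand for weaker inhibition and lower numbers for stronger inhibition. Compound 2 sits at the low end of the three numbers: in this assay compound 2 gives 8000 nM, and compound 3 gives 8000 nM, the same at the digits shown and therefore within the scatter. Compound 1 gives 66000 nM, the highest of the three.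

The unmeasured compound 4, `COc1ccccc1NC(=S)NC1CC(C)(C)Oc2ccc(Br)cc21`, differs from compound 2 by 2-methoxyphenyl in place of 3-chlorophenyl on an amide-type nitrogen. For the measured compounds named here, one measured step bears on this: an 8.3-fold lower number from compound 1 to compound 2 (0.92 log units; beyond the scatter). Going by the values given here, compound 4 reverses the direction of that step, reinstating a methoxy group on the phenyl ring, though at a different position on the ring, for which no measured pair gives guidance. The expectation is therefore that compound 4 will give a higher number than compound 2, roughly undoing the earlier step, with wide uncertainty because the position of the methoxy group is new. The expected step is a 5.0-fold higher number from compound 2 to compound 4 (0.70 log units; beyond the scatter). For compound 4 the estimate in this assay is 40000 nM, with a range from 10000 nM to 120000 nM.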

Compound 4, half-maximal inhibitory concentration: 22000 nM
Compound 4: middle estimate off by 1.8-fold (0.26 log units), on the high side; the measured number falls inside the stated range.
By their numbers in this assay, from the lowest: compounds 2 and 3 (each within the scatter of the next); then compound 4; then compound 1.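

In this assay, for the compounds shown here, replacing 3-methoxyphenyl with 2-methoxyphenyl on the amide-type nitrogen gives a 3.0-fold lower number from compound 1 to compound 4 (0.48 log units; beyond the scatter), the first measured pair here in which the methoxy group changes its place on the phenyl ring while everything else stays the same, so the outcome at this nitrogen depends on where the methoxy group sits and not only on whether it is present. Replacing 3-chlorophenyl with 2-methoxyphenyl gives a 2.8-fold higher number from compound 2 to compound 4 (0.44 log units; beyond the scatter), so neither methoxy-bearing compound reaches the level of compound 2, although this step changes the substituent and its ring position together and cannot show how much each contributes. Nothing measured alongside these numbers explains either step.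

From the compounds shown here alone, a chloro group at the ring position held by the methoxy group in compound 4 would separate the effect of the substituent from that of its position, and that comparison remains open. Going by these compounds, it also remains open whether other groups on this phenyl ring, such as an amine, a carboxylic acid or a longer ether chain, would give higher or lower numbers than those seen so far.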